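The source may report more compounds than this note shows. Statements on the series, on what has been measured and on what is new or still open speak of the compounds shown alone.

Among the measured compounds shown here, compound 2 `CN1CCN(c2ccc(NC(=N)c3cc4cnn(C)c4cn3)cc2)CC1` shows the lowest of the two numbers so far: in a functional assay on MDA-MB-231 cells (Homo sapiens) for cytotoxicity, read by MTT assay, with a stated time of 72 h (a lower number here means a stronger inhibitor, a higher number a weaker inhibitor), compound 2 gives 30200 nM. Compound 1 `CN1CCN(c2ccc(NC(=N)c3cc4cn[nH]c4cn3)cc2)CC1` gives 47500 nM, and the step of a 1.6-fold lower number from compound 1 to compound 2 (0.20 log units; within the scatter) lies within the scatter. Compound 3 `COc1ccc(Cn2ncc3cc(C(=N)Nc4ccc(N5CCN(C)CC5)cc4)ncc32)cc1` differs from compound 2 by 4-methoxyphenyl in place of hydrogen on a saturated chain carbon bound to an aromatic nitrogen. For the measured compounds named here, the only measured step, methyl for hydrogen on an aromatic nitrogen, changed little and is a different kind of change, so it bears only loosely on this larger addition. The step of a 2.0-fold lower number from compound 2 to compound 3 (0.30 log units; within the scatter) is expected to be modest, toward a lower number. Compound 3 is estimated at 15000 nM, within 4000 nM to 60000 nM.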

Compound 3, half-maximal inhibitory concentration: 5700 nM
For compound 3 the middle estimate is 2.6-fold (0.42 log units) above the measured one; low and high end bracket the measured number.
By their numbers in this assay, from the lowest: compound 3; then compounds 2 and 1 (each within the scatter of the next).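

In this assay, the group on this aromatic nitrogen can shift the number after all: 4-methoxybenzyl gives a 5.3-fold lower number from compound 2 to compound 3 (0.72 log units; beyond the scatter) and also an 8.3-fold lower number from compound 1 to compound 3 (0.92 log units; beyond the scatter). Both steps lie beyond the scatter, which the methyl step gave no sign of. No measurement shown explains this gain.
The compounds shown leave open whether the step comes from the aromatic ring or from its methoxy group, which plain benzyl would separate. They also leave open how an amine or a carboxylic acid in the methoxy group's place would read.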